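From compound 1 to compound 4: a smaller amine group

The source may hold more compounds than are shown below. What is called first, only, known or untested is meant among the compounds shown, and "the series" means these compounds.

Measured so far in a physicochemical assay for acid dissociation, are three compounds:
- compound 1 `Cc1csc2cc([C@H](C)Nc3ncnc(N)c3C#N)c(-c3cccc(CN4CCC(CN(C)CC(C)C)CC4)c3)c(=O)n12` at 9.8
- compound 2 `Cc1csc2cc([C@H](C)Nc3ncnc(N)c3C#N)c(-c3cccc(CN(C)CCCN(C)Cc4ccc(Cl)cc4)c3)c(=O)n12` at 8.8
- compound 3 `Cc1csc2cc([C@H](C)Nc3ncnc(N)c3C#N)c(-c3cccc(CN(C)CCCN4C[C@@H](C)O[C@@H](C)C4)c3)c(=O)n12` at 8.5

Compound 1 stands highest of the three, and both compound 2 and compound 3 lie beyond the scatter from it. Compound 4 `Cc1csc2cc([C@H](C)Nc3ncnc(N)c3C#N)c(-c3cccc(CN4CCC(N(C)C)CC4)c3)c(=O)n12` has yet to be measured. It differs from compound 1 in one place dimethylamino in place of (isobutyl(methyl)amino)methyl on a saturated ring carbon with dimethylamino in place of (isobutyl(methyl)amino)methyl on a saturated ring carbon, three ring bonds from the ring nitrogen.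

Among the compounds with values here, the only measured step between two compounds that differ in one place is a number 0.30 log units lower from compound 2 to compound 3 (within the scatter) and it sits on a saturated chain carbon, not a ring carbon, so it bears on this change only loosely. Within the data shown here, no measured compound other than compound 1 carries this ring, and so nothing measured isolates the exchange. The values of compound 2 at 8.8 and compound 3 at 8.5 mark how far this series has been seen to lie from compound 1.

A moderate step of a number 0.60 log units lower from compound 1 to compound 4 (beyond the scatter) is therefore expected in this assay with real uncertainty about its size. For compound 4 the estimated value is 9.2 within an expected range of 8.7 to 9.7 on present evidence.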

Compound 4, acid dissociation constant: 9.5
For compound 4 the middle estimate is 0.30 log units below the measured one; measured number inside the range.
By their numbers in this assay, from the lowest: compounds 3 and 2 (each within the scatter of the next); then compounds 4 and 1 (each within the scatter of the next).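

In this assay, dimethylamino in place of (isobutyl(methyl)amino)methyl on a saturated ring carbon, three ring bonds from the ring nitrogen, gives a number 0.30 log units lower from compound 1 to compound 4 (within the scatter), so the two values cannot be told apart even though the entering group has 3 heavy atoms and the leaving group has 7. This is the only step shown at a ring carbon, and it shows that, in this one pair, the read-out stays within the scatter when the (isobutyl(methyl)amino)methyl group is exchanged for the smaller dimethylamino group. No supporting measurement accompanies this result, so it gives the size of the step but offers no explanation for it.

Still open, from the compounds shown here alone, is whether other groups on the same ring carbon, such as a primary amine, a pyrrolidine, a hydroxyl or a carboxylic acid, would also stay within the scatter of compound 1 in this assay. The compounds shown also leave open whether a longer chain between this ring carbon and its amine nitrogen would change the read-out, and which of the nitrogens in these compounds the read-out reports.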